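This account rests on a few compounds, and the source may have more. Where it says the series, first, only, none or still open, it means among the compounds named here.

Measured compounds:
compound 1 `CC/C=C\Cn1c(Cc2cc(OC)c(OC)c(OC)c2)nc2c(N)ncnc21`; in a functional assay on MCF7 cells (Homo sapiens) for antiproliferative activity (a higher number here means a weaker inhibitor, a lower number a stronger inhibitor), compound 1 gives 64600 nM.
compound 2 `C#CCCCn1c(Cc2cc(OC)c(OC)c(OC)c2)nc2c(N)nc(F)nc21`; in this assay compound 2 gives 11000 nM.
compound 3 `COCCn1c(Cc2cc(OC)c(OC)c(OC)c2)nc2c(N)nc(F)nc21`; in this assay compound 3 gives 64600 nM.

Compound 1 stands level with compound 3 at the digits given, and together they carry the highest numbers of the three; the number for compound 2 lies beyond the scatter below both. Among the compounds with values here, the one step between compounds differing in a single place is a 5.9-fold higher number from compound 2 to compound 3 (0.77 log units; beyond the scatter), the change being methoxy in place of propargyl on a saturated chain carbon, two bonds along the chain from an aromatic nitrogen.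

Compound 4 `CCC(C)Cn1c(Cc2cc(OC)c(OC)c(OC)c2)nc2c(N)ncnc21` differs from compound 1 by sec-butyl in place of but-1-en-1-yl on a saturated chain carbon bound to an aromatic nitrogen. Within the data shown here, no measured step addresses this change: the step from compound 2 to compound 3 concerns other groups at another place on the chain, and compound 1 carries no fluorine on the core where compounds 2 and 3 do. With nothing in the series speaking for either direction, the expectation in this assay is a step no larger than the scatter, a 1.3-fold lower number from compound 1 to compound 4 (0.11 log units; within the scatter). Compound 4 is therefore estimated at 50000 nM, within 18000 nM to 140000 nM.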

Compound 4, half-maximal inhibitory concentration: 61700 nM
Beside the measured number, compound 4's estimate is 1.2-fold (0.09 log units) below it, within the range that was stated.
By their numbers in this assay, from the lowest: compound 2; then compounds 4, 1 and 3 (each within the scatter of the next).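

In this assay the change to sec-butyl on a saturated chain carbon bound to an aromatic nitrogen is a 1.0-fold lower number from compound 1 to compound 4 (0.02 log units; within the scatter) and so stays within the scatter. For this one pair, on the core without fluorine, the double bond of but-1-en-1-yl and the branch of sec-butyl read alike at this place, which the earlier step between propargyl and methoxy could not show. No other measurement here bears on why the two groups read alike.

Still open, as far as these compounds go, is whether an amine, a carboxylic acid, a longer chain or a cyclohexyl group at this place would move the number. Within the data shown here, also open is whether the same change reads alike on the core carrying fluorine, where the only step available is a 5.9-fold higher number from compound 2 to compound 3 (0.77 log units; beyond the scatter) and concerns other groups.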